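The source may report more compounds than this note shows. Statements on the series, on what has been measured and on what is new or still open speak of the compounds shown alone.

Compound 1, `Cc1ccc(OCC(=O)N(Cc2cccs2)c2ccn[nH]2)cc1`, gives the highest of the three numbers recorded so far in a physicochemical assay for solubility, measured as thermodynamic solubility, at pH 7.1 (on this read-out higher numbers stand for higher solubility and lower numbers for lower solubility), where compound 1 reads 189000 nM. Compound 3, `CCN(Cc1cccs1)C(=O)COc1ccc2c(c1)CCC2`, comes nearest to it; in this assay compound 3 gives 85000 nM, a gap that lies beyond the usual scatter. Compound 2, `CCN(Cc1cccs1)C(=O)c1cc2cc(OC)ccc2o1`, stands furthest away, giving 49000 nM in this assay.

Compound 4, `CCN(Cc1cccs1)C(=O)COc1ccc(C)cc1`, has not yet been measured. It differs from compound 1 in one place: ethyl in place of 1H-pyrazol-5-yl on an amide-type nitrogen. For the measured compounds named here, no measured pair shows this exact step, so its size can only be expected, not read off. Compounds 2 and 3 both carry an ethyl on the amide-type nitrogen, and both sit below compound 1 in this assay. On that basis the step of a 2.1-fold lower number from compound 1 to compound 4 (0.32 log units; beyond the scatter) is expected to be a decrease of moderate size, somewhat beyond the scatter, because compound 3 gives 85000 nM and compound 2 gives 49000 nM. Compound 4 is therefore estimated at 90000 nM, with a plausible range from 40000 nM to 200000 nM.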

Compound 4, solubility: 545000 nM
For compound 4 the middle estimate is 6.1-fold (0.78 log units) below the measured one, and the stated range ends below it.
By their numbers in this assay, from the lowest: compounds 2 and 3 (each within the scatter of the next); then compound 1; then compound 4.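

In this assay, for the compounds shown here, the step with ethyl in place of 1H-pyrazol-5-yl on the amide-type nitrogen gives a 2.9-fold higher number from compound 1 to compound 4 (0.46 log units; beyond the scatter), the first step in which only this position changes. It shows that the read-out responds to the group at this position, and that the ring of 1H-pyrazol-5-yl is not needed for a high number here, since ethyl, which has no ring, gives the higher number on the same core. No measurement shown accounts for this rise.

A single step cannot tell whether the rise comes from losing 1H-pyrazol-5-yl or from gaining ethyl. Going by these compounds, how a methyl, a longer chain such as butyl, a chain ending in an amine or one ending in a carboxylic acid would read on this nitrogen remains open.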